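Ethyl for methyl on the retained methoxycarbonyl of compound 2

The compounds below may be only part of what the source reports. "The series", "measured", "known", "first", "only" and "open" are said of these compounds alone.

Compound 2 `CCCOC(=O)C1=C(C)NC(C)=C(C(=O)OC)C1c1[nH]c(CC)nc1Cl` holds the lowest number of the three measured in an assay on ileum for inhibition of Voltage-dependent L-type calcium channel subunit alpha-1C (Cavia porcellus) (a lower number here means a stronger inhibitor, a higher number a weaker inhibitor), where compound 2 gives 0.146 nM. Compound 3 `CCc1nc(Cl)c(C2C(C(=O)OC)=C(C)NC(C)=C2C(=O)OC(C)C)[nH]1` gives 0.488 nM, and compound 1 `CCc1nc(Cl)c(C2C(C(=O)OC)=C(C)NC(C)=C2C(=O)OC)[nH]1` gives 0.596 nM; both steps from compound 2 lie beyond the scatter, so compound 2 stands apart as the strongest inhibitor of the three.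

Compound 4 `CCCOC(=O)C1=C(C)NC(C)=C(C(=O)OCC)C1c1[nH]c(CC)nc1Cl` differs from compound 2 by methyl in place of hydrogen on a saturated chain carbon bound to an oxygen next to a carbonyl group; read one bond further out, the methoxycarbonyl becomes an ethoxycarbonyl.

For the measured compounds named here, two measured steps bear on this. The closest is the change on the same methoxycarbonyl, isopropyl in place of methyl, which gave a 1.2-fold lower number from compound 1 to compound 3 (0.09 log units; within the scatter). The step that gave a 4.1-fold lower number from compound 1 to compound 2 (0.61 log units; beyond the scatter) concerns the chain that compound 2 already carries, and a 3.3-fold higher number from compound 2 to compound 3 (0.52 log units; beyond the scatter) shows that shortening or branching that chain costs a modest amount. Going by the values given here, a methyl added to the other chain is a smaller change than either of those, and the nearest precedent, from compound 1 to compound 3, stayed within the scatter.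

For compound 4 a step of a 1.2-fold lower number from compound 2 to compound 4 (0.09 log units; within the scatter) in this assay is therefore expected, no larger than the scatter. Compound 4 is estimated at 0.12 nM, with a range from 0.05 nM to 0.3 nM.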

Compound 4, half-maximal inhibitory concentration: 0.543 nM
Beside the measured number, compound 4's estimate is 4.5-fold (0.66 log units) below it; measured number outside the range, above it.
By their numbers in this assay, from the lowest: compound 2; then compounds 3, 4 and 1 (each within the scatter of the next).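

Adding one methyl to the retained methoxycarbonyl is not a silent change: in this assay it gives a 3.7-fold higher number from compound 2 to compound 4 (0.57 log units; beyond the scatter), even though the nearest earlier change on a methoxycarbonyl, a 1.2-fold lower number from compound 1 to compound 3 (0.09 log units; within the scatter), was small. That earlier step had a methoxycarbonyl on the other side, whereas here the propyl ester stays in place, so the size of a change at one ester cannot be carried over from a compound with a different partner ester. With a 3.3-fold higher number from compound 2 to compound 3 (0.52 log units; beyond the scatter) alongside the new step, compound 2 is now the strongest inhibitor of the four, and both single changes away from it raise the number by similar modest amounts; no measurement shown accounts for this.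

It remains open whether the ethoxycarbonyl would carry the same penalty with a methoxycarbonyl on the other side, since the compounds shown offer no such one-place comparison. Also open, as far as these compounds go, is how this position responds to a longer chain such as butyl on the oxygen next to the carbonyl, or to a carboxylic acid in place of the ester.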